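A larger amine on compound 3: what to expect

A few compounds are considered here, and "the series" means these few. Any claim that something is new, unique, unknown or untested is made for them only; others in the source may bear on it.

Three related compounds have been measured: compound 1 (`CN(C)c1nc(Cl)nc2c1ncn2CCNc1ccnc2cc(Cl)ccc12`), compound 2 (`CCN(CC)c1nc(Cl)nc2c1ncn2CCNc1ccnc2cc(Cl)ccc12`) and compound 3 (`CN(C)c1nc(Cl)nc2c1ncn2CCCNc1ccnc2cc(Cl)ccc12`). In an ADME assay on Vero cells (Chlorocebus sabaeus) for cytotoxicity, read by neutral red uptake, with a stated time of 48 h (on this read-out higher numbers stand for weaker inhibition and lower numbers for stronger inhibition), compound 1 gives > 11800 nM and this is a limit of the assay, not a number. Compound 2 gives > 11000 nM and this too is a limit. Compound 3 gives > 11400 nM and this is also a limit, so its place among the three cannot be ranked.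

Compound 4 (`CCN1CCN(c2nc(Cl)nc3c2ncn3CCCNc2ccnc3cc(Cl)ccc23)CC1`) differs from compound 3 in one place, with 4-ethylpiperazin-1-yl in place of dimethylamino on an aromatic carbon. The nearest measured change is a step that the two limits leave unreadable from compound 1 to compound 2 and it also exchanges one amino group for another, yet it gives no size to carry over. For the measured compounds named here, no measured compound carries a ring in this place, so the guidance is thin. In this assay the expected change is an at least 1.2-fold lower number from compound 3 to compound 4 (0.07 log units; that floor lies within the scatter) with no shift beyond the scatter expected in either direction. For compound 4 the estimated value in this assay is 9500 nM with an expected range from 3500 nM to 20000 nM and the result could again be only a limit.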

Compound 4, half-maximal inhibitory concentration: > 9830 nM
Compound 4: a limit, no number; the forecaster's own chance of this, stated with the estimate: 70%; middle value at least 1.0-fold (0.01 log units) away from the limit.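

Compound 3 and compound 4 both give only a limit in this assay, not a number, so the step between them cannot be read. The compounds shown leave open whether exchanging dimethylamino for diethylamino or 4-ethylpiperazin-1-yl changes the half-maximal inhibitory concentration at all, and if it does, in which direction and by how much.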